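A few compounds are considered here, and "the series" means these few. Any claim that something is new, unique, unknown or untested is made for them only; others in the source may bear on it.

Of the compounds shown here, two have been measured in a functional assay on K562 cells (Homo sapiens) for antiproliferative activity, read by CellTiter-Glo, with a stated time of 72 h; a higher number here means that more compound is needed for the effect, a lower number that less compound is needed.
Compound 1, `CCCCCCCNc1ncnc2c1ncn2[C@@H]1O[C@H](COS(N)(=O)=O)[C@@H](O)[C@H]1O`: 132 nM
Compound 2, `COCCNc1ncnc2c1ncn2[C@@H]1O[C@H](COS(N)(=O)=O)[C@@H](O)[C@H]1O`: > 1000 nM, which is a limit of the assay rather than a number.

Compound 1 thus holds the only number shown. Going by the values given here, the single measured step, an at least 7.5-fold higher number from compound 1 to compound 2 (0.87 log units; beyond the scatter), is the only guide to the untested compound 3, `NS(=O)(=O)OC[C@H]1O[C@@H](n2cnc3c(NCC4CCCO4)ncnc32)[C@H](O)[C@@H]1O`, where (oxolan-2-yl in place of hexyl on a saturated chain carbon bound to a nitrogen on an aromatic ring). That change likewise shortens the chain and brings in one hydrogen-bond acceptor, so a rise beyond the scatter is expected, though the measured step reaches only (the limit of > 1000 nM in this assay, at which 1 of the 2 values shown sits). Compound 3 is estimated at 600 nM, between 200 nM and 3000 nM, an expected step of a 4.5-fold higher number from compound 1 to compound 3 (0.66 log units; beyond the scatter).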

Compound 3, half-maximal effective concentration: > 1000 nM
Compound 3: a limit, no number; the forecaster's own chance of this, stated with the estimate: 35%; at least 1.6-fold (0.22 log units) between middle value and limit.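

In this assay, oxolan-2-yl at this place, on a saturated chain carbon bound to a nitrogen on an aromatic ring, gives an at least 7.5-fold higher number from compound 1 to compound 3 (0.87 log units; beyond the scatter), so a group with a ring raises the number as the open methoxy chain of compound 2 did. The value of compound 3 is a limit of the assay, and the step between compound 2 and compound 3 cannot be read, since both values are limits. Most of the compounds shown now sit at that limit: the limit of > 1000 nM in this assay, at which 2 of the 3 values shown sit.

Going by these compounds, how far compound 2 and compound 3 lie past it remains open. Also open, on these data alone, is whether cyclopentyl, which has the ring without its oxygen, or a chain longer than hexyl, would hold or improve on the value of compound 1, 132 nM.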